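This account rests on a few compounds, and the source may have more. Where it says the series, first, only, none or still open, it means among the compounds named here.

Working notes on this series, cytotoxicity readout.

Compound 1 `COc1cccc(/C=C2\CCC/C(=C\c3cccc(OC)c3OC)C2=O)c1` is the reference. In a functional assay on A549 cells (Homo sapiens) for cytotoxicity, read by MTT assay, with a stated time of 72 h (a lower number here means a stronger inhibitor, a higher number a weaker inhibitor), compound 1 gives 16400 nM. Compound 2 `COc1cc(/C=C2\CCC/C(=C\c3cccc(OC)c3OC)C2=O)cc(OC)c1` carries one more methoxy; the change is methoxy in place of hydrogen on an aromatic carbon. In this assay compound 2 gives 10200 nM. Going by the values given here, the step of a 1.6-fold lower number from compound 1 to compound 2 (0.21 log units; within the scatter) is the only measured instance of this change, and it sits inside the scatter, so the two values are treated as equivalent.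

Compound 3 `COc1ccc(/C=C2\CCC/C(=C\c3ccc(OC)c(OC)c3)C2=O)cc1` has the same atoms as compound 1 joined differently; the difference between the two cores is not broken down here. In this assay compound 3 reaches only a limit of the assay, > 20000 nM, with no number behind it; this is the limit described as the limit of > 20000 nM in this assay, at which 1 of the 3 values shown sits, and one of the three measured values sits there.

Compound 4 `COc1ccc(/C=C2\CCC/C(=C\c3ccc(OC)c(OC)c3)C2=O)cc1OC` is not yet measured. It differs from compound 3 by methoxy in place of hydrogen on an aromatic carbon. This is the same kind of change as methoxy in place of hydrogen on an aromatic carbon, not the same one: in the one case the new methoxy stands ortho to a methoxy group and meta to a large group, in the other meta to a large group and meta to a methoxy group. For compound 4 a step that the limit leaves unreadable from compound 3 to compound 4 in this assay is expected, set beside a 1.6-fold lower number from compound 1 to compound 2 (0.21 log units; within the scatter), because that earlier step from a measured pair is within the scatter and compound 3 offers only the limit > 20000 nM as a starting point. Compound 4 is therefore estimated at 22000 nM, with a range from 9000 nM to 60000 nM, and a fair chance that the assay again returns only a limit.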

Compound 4, half-maximal inhibitory concentration: 8500 nM
Estimate against measurement, compound 4: 2.6-fold (0.41 log units) above; the whole stated range lies above it.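

In this assay methoxy in place of hydrogen on an aromatic carbon gives an at least 2.3-fold lower number from compound 3 to compound 4 (0.37 log units; beyond the scatter), and here the new methoxy stands ortho to a methoxy group and meta to a large group. For compound 3 the value > 20000 nM is a limit of the assay and not a number, so this step has a floor but no fixed size. The result shows that the change can go with a lower number on the core of compound 3, but it does not show that the step carries over from one core to another with the same size or a different one: the same change on two cores in this assay, a 1.6-fold lower number (0.21 log units; within the scatter) from compound 1 to compound 2 and an at least 2.3-fold lower number (0.37 log units; beyond the scatter) from compound 3 to compound 4; the limit leaves it open whether they differ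

Going by these compounds alone, only two instances of this change stand here, one on each core and with the added methoxy in a different place on the ring, so no rule for placing a methoxy can be drawn from them. All the compounds shown carry only methoxy groups on their aromatic rings, which leaves open how an amine, a carboxylic acid or a longer chain at these places would read in this assay.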